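This account rests on a few compounds, and the source may have more. Where it says the series, first, only, none or still open, it means among the compounds named here.

Compound 1 `CCOC(=O)C1=Cc2ccccc2OC1(OCc1cc(-c2ccc(C)cc2)no1)C(F)(F)F` is the ethyl ester of the series. Among the measured compounds shown here, in a functional assay on MCF7 cells (Homo sapiens) for inhibition, read by MTT assay, with a stated time of 24 h (a lower number here means a stronger inhibitor, a higher number a weaker inhibitor), compound 1 gives only a limit of the assay, > 150000 nM, so its true value is not pinned down, and the limit of > 150000 nM in this assay, at which 1 of the 3 values shown sits, marks it as the one value among the three that sits at that limit. Its acid counterpart, compound 2 `Cc1ccc(-c2cc(COC3(C(F)(F)F)Oc4ccccc4C=C3C(=O)O)on2)cc1`, gives 30100 nM in this assay. For the measured compounds named here, the step of an at least 4.9-fold lower number from compound 1 to compound 2 (0.69 log units; beyond the scatter) is the only measured change of a single group in this set. Compound 3 `CCOC(=O)C1=Cc2ccccc2OC1(OCc1cn(-c2ccc(F)c(Cl)c2)nn1)C(F)(F)F`, which carries a different ring and a different aryl group, gives 25300 nM in this assay.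

Compound 4 `CCOC(=O)C1=Cc2ccccc2OC1(OCc1cc(-c2ccc(F)cc2)no1)C(F)(F)F` differs from compound 1 by fluoro in place of methyl on an aromatic carbon. Going by the values given here, no measured step touches this position: the one step that is known concerns the ester, not the aryl group, and it gives no guidance on swapping a methyl for a fluoro there. With nothing to suggest movement, compound 4 is expected to remain near where compound 1 stands, and the step of a number no higher from compound 1 to compound 4 (the limit leaves the size open) is expected to be none beyond the scatter. The estimate for compound 4 in this assay is therefore 150000 nM, with a range from 40000 nM to 600000 nM, and a real chance that only a limit is reported again.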

Compound 4, half-maximal inhibitory concentration: 48200 nM
Beside the measured number, compound 4's estimate is 3.1-fold (0.49 log units) above it; the measured number falls inside the stated range.
By their numbers in this assay, from the lowest: compounds 3, 2 and 4 (each within the scatter of the next). At a limit, above all of these: compound 1.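

Moving from 4-methylphenyl to 4-fluorophenyl is the first measured change on the aryl group, and in this assay it gives an at least 3.1-fold lower number from compound 1 to compound 4 (0.49 log units; beyond the scatter). This shows that the position para to a large group is not silent: exchanging methyl for fluoro, one heavy atom for one heavy atom, is enough to bring the ethyl ester series to a measured number, so compound 1 now has single changes at both the ester and the aryl group that lead to measured values. The true size of this step stays unknown, because the value of compound 1 is a limit of the assay and not a number: the limit of > 150000 nM in this assay, at which 1 of the 4 values shown sits.

The compounds shown leave open how this position responds to other groups, such as a methoxy group, an amine or a bare hydrogen in place of the fluoro, so a single exchange cannot yet show a trend there. They also leave open whether the change from methyl to fluoro and the change from ethyl ester to carboxylic acid would hold when combined on the shared core in one compound.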